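Cytotoxicity notes on a carbonyl-to-benzyl swap

The source may hold more compounds than are shown below. What is called first, only, known or untested is meant among the compounds shown, and "the series" means these compounds.

Measured compounds:
compound 1 `CC(=O)c1ccn(-c2ccc3c(c2)B(O)OC3)c1`: > 10 ug/mL
compound 2 `O=C(c1ccc(Cl)cc1)c1ccn(-c2ccc3c(c2)B(O)OC3)c1`: > 10 ug/mL
compound 3 `O=C(c1ccc(O)cc1)c1ccn(-c2ccc3c(c2)B(O)OC3)c1`: > 10 ug/mL

In an ADME assay on L929 cells (Mus musculus) for cytotoxicity, read by resazurin assay, with a stated time of 72 h (on this read-out lower numbers stand for stronger inhibition and higher numbers for weaker inhibition), compound 1 gives > 10 ug/mL, which is a limit of the assay and not a number. Compound 2 gives > 10 ug/mL in this assay, again a limit. Compound 3 gives > 10 ug/mL in this assay, also a limit. All three values sit at the limit of > 10 ug/mL in this assay, at which 3 of the 3 values shown sit. The steps a step that the two limits leave unreadable from compound 1 to compound 2, a step that the two limits leave unreadable from compound 1 to compound 3 and a step that the two limits leave unreadable from compound 2 to compound 3 therefore carry no readable size. Compound 4 `OB1OCc2ccc(-n3ccc(Cc4ccccc4)c3)cc21` differs from compound 1 by benzyl in place of acetyl on an aromatic carbon. The two measured steps that start from compound 1 replace the methyl on the carbonyl carbon and keep the carbonyl, whereas the change to compound 4 removes the carbonyl and brings in benzyl; they bear on it only loosely, and in any case their sizes are hidden by the limits. With every measured value at the limit, the expected step that the limit leaves unreadable from compound 1 to compound 4 is set at no change beyond the scatter, most likely ending at the same limit. Compound 4 is estimated at 15 ug/mL, within 5 ug/mL to 45 ug/mL.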

Compound 4, half-maximal inhibitory concentration: > 10 ug/mL
Compound 4 gave a limit, no number; the forecaster's own chance of this, stated with the estimate: 70%; the middle value lies beyond the limit too.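

Compound 4 gives > 10 ug/mL in this assay, a limit and not a number. No step among compound 1, compound 2, compound 3 and compound 4 can be read: the limit of > 10 ug/mL in this assay, at which 4 of the 4 values shown sit.

The compounds shown leave open which change on the shared core, if any, would yield a measurable value.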